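The source may hold more compounds than are shown below. What is called first, only, known or untested is meant among the compounds shown, and "the series" means these compounds.

Measured so far in a functional assay on Jurkat cells (Homo sapiens) for cytotoxicity, with a stated time of 72 h (a higher number here means that more compound is needed for the effect, a lower number that less compound is needed), and known only as limits:
compound 1 `C=C[C@@](C)(/C=C/c1ccc(O)cc1)CC/C=C(\C)CO` gives > 49000 nM as a limit
compound 2 `COc1ccc(/C=C/[C@@](C)(/C=C/c2ccc(O)c(C=O)c2)CCC=C(C)C)cc1` gives > 49000 nM as a limit

Compound 2 stands at > 49000 nM as a limit and not as a number. Going by the values given here, the data so far amount to the limit of > 49000 nM in this assay, at which 2 of the 2 values shown sit, and hold no measured step. Compound 3 `COc1ccc(/C=C/[C@@](C)(/C=C/c2ccc(O)c(/C=C/C(C)=O)c2)CCC=C(C)C)cc1` differs from compound 2 in one place 2-acetylethenyl in place of formyl on an aromatic carbon with 2-acetylethenyl in place of formyl on an aromatic carbon, ortho to a hydroxy group. In this assay no measured change gives a size for this swap. The expectation is therefore loose: a modest shift toward less compound needed, perhaps none beyond the scatter, and compound 3 may well stay at the limit. The expected at least 1.9-fold lower number from compound 2 to compound 3 (0.29 log units; that floor lies within the scatter) is an estimate set against a limit. For compound 3 the estimated value is 25000 nM with an expected range from 8000 nM to 49000 nM for now.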

Compound 3, half-maximal effective concentration: > 49000 nM
Compound 3: only a limit was reported; the forecaster's own chance of this, stated with the estimate: 55%; middle value at least 1.9-fold (0.29 log units) from the limit.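

Between compound 2 and compound 3 no step can be read in this assay, since both are known only as limits: the limit of > 49000 nM in this assay, at which 3 of the 3 values shown sit.

The compounds shown leave open whether 2-acetylethenyl in place of formyl on an aromatic carbon changes the concentration needed at all, and in which direction.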